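The compounds below may be only part of what the source reports. "The series", "measured", "known", "first", "only" and "open" are said of these compounds alone.

Measured compounds in a functional assay on HeLa cells (Homo sapiens) for cytotoxicity, read by CCK-8 assay; a higher number here means a weaker inhibitor, a lower number a stronger inhibitor:
- Compound 1, `Oc1cccc(-c2cc(-c3cccs3)cc(-c3ccccc3O)n2)c1`: in this assay compound 1 gives > 50000 nM, which is a limit of the assay rather than a number.
- Compound 2, `Oc1ccc(-c2cc(-c3cccs3)cc(-c3cccc(O)c3)n2)cc1`: in this assay compound 2 gives 4140 nM.

Compound 1 therefore stands at the edge of what this assay can report, the upper limit (the limit of > 50000 nM in this assay, at which 1 of the 2 values shown sits), and only a bound is known for it. Within the data shown here, the one measured step, an at least 12-fold lower number from compound 1 to compound 2 (1.08 log units; beyond the scatter), moves a hydroxyl group on one of the phenyl rings and leaves the thiophene untouched, so it says nothing direct about the change examined here.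

Compound 3, `Oc1cccc(-c2cc(-c3ccccn3)cc(-c3ccccc3O)n2)c1`, differs from compound 1 by pyridin-2-yl in place of thiophen-2-yl on an aromatic carbon. Among the measured compounds shown here, no measured step covers a swap of this ring, so there is no basis for expecting a shift beyond the scatter in either direction; the starting point being a limit, the most likely outcome is that compound 3 also returns only a limit. Compound 3 is estimated to give 60000 nM, with a range from 15000 nM to 250000 nM. This estimate corresponds to the expected step that the limit leaves unreadable from compound 1 to compound 3, essentially no change.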

Compound 3, half-maximal inhibitory concentration: 2020 nM
The estimate for compound 3 lay 30-fold (1.47 log units) above the measured number, and the stated range ends above it.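

In this assay, the position opposite the ring nitrogen proves able to change the result on its own: with both hydroxyphenyl groups left as they are, pyridin-2-yl in place of thiophen-2-yl gives an at least 24-fold lower number from compound 1 to compound 3 (1.39 log units; beyond the scatter). Among these compounds, the earlier step involved only the hydroxyphenyl groups, so this is the first sign that the ring at this position also matters, and that a compound at the limit of the assay can be brought to a measurable value without touching those groups. As far as these compounds go, the true size of this step remains unknown, because compound 1 has only a limit and not a number: the limit of > 50000 nM in this assay, at which 1 of the 3 values shown sits.

One swap cannot separate the effect of the ring nitrogen from that of going from a five-membered to a six-membered ring, and an unsubstituted phenyl ring or a pyridin-4-yl group at the same position would help to tell these apart. From the compounds shown here alone, it also remains open whether pyridin-2-yl would give a similar step with the hydroxyphenyl groups of compound 2, and whether a non-aromatic group such as morpholine would be tolerated here.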